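The source may hold more compounds than are shown below. What is called first, only, known or untested is meant among the compounds shown, and "the series" means these compounds.

Compound 3 `CNc1cc(=O)oc2cc(OCc3cccc(Cl)c3)ccc12` stands at the lowest number of the three measured compounds in an assay on isolated protein (strain Sprague-Dawley) for inhibition of Amine oxidase [flavin-containing] B (Rattus norvegicus), read by spectrophotometry, with a stated time of 5 min (on this read-out lower numbers stand for stronger inhibition and higher numbers for weaker inhibition), giving 8.71 nM. Compound 1 `CCOc1cc(=O)oc2cc(OCc3cccc(Cl)c3)ccc12` gives 115 nM in this assay, and compound 2 `CCOC(=O)Nc1cc(=O)oc2cc(OCc3cccc(Cl)c3)ccc12` gives 589 nM. Compound 4 `O=Cc1cc(=O)oc2cc(OCc3cccc(Cl)c3)ccc12` has not yet been measured; it differs from compound 3 by formyl in place of methylamino on an aromatic carbon. Among the measured compounds shown here, two measured steps bear on this change: the step of a 13-fold lower number from compound 1 to compound 3 (1.12 log units; beyond the scatter) shows how much the methylamino group brought the number down, and the step of a 68-fold lower number from compound 2 to compound 3 (1.83 log units; beyond the scatter) shows that a carbonyl-bearing group in its place gave a far higher number, with the step of a 5.1-fold higher number from compound 1 to compound 2 (0.71 log units; beyond the scatter) pointing the same way. Compound 4 is therefore expected to give a higher number than compound 3, a step of a 17-fold higher number from compound 3 to compound 4 (1.24 log units; beyond the scatter). The value of compound 4 is estimated at 150 nM, within 30 nM to 700 nM.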

Compound 4, half-maximal inhibitory concentration: 52.5 nM
For compound 4 the middle estimate is 2.9-fold (0.46 log units) above the measured one; the measured number falls inside the stated range.
By their numbers in this assay, from the lowest: compound 3; then compound 4; then compound 1; then compound 2.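

A carbonyl-bearing group on this carbon does not by itself raise the number: formyl stands below ethoxy (a 2.2-fold lower number from compound 1 to compound 4 (0.34 log units; beyond the scatter)) and well below (ethoxycarbonyl)amino (an 11-fold lower number from compound 2 to compound 4 (1.05 log units; beyond the scatter)). Methylamino still gives the lowest number of the four, though replacing it with formyl costs less than replacing it with (ethoxycarbonyl)amino did (a 6.0-fold higher number from compound 3 to compound 4 (0.78 log units; beyond the scatter)). As far as these compounds go, whether an unsubstituted amine or a carboxylic acid on this carbon would fall nearer methylamino or formyl remains open. Nothing measured here explains the order of these groups.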